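Removing a Ring Fluorine from a Furanylmethyl Quinazoline Diamine

This account rests on a few compounds, and the source may have more. Where it says the series, first, only, none or still open, it means among the compounds named here.

The measured compounds and their values in a functional assay on HT-29 cells (Homo sapiens) for cytotoxicity, read by MTT assay, with a stated time of 2 days, tested at 10 uM; a lower number here means less inhibition, a higher number more inhibition at the concentration tested (going by the name of the read-out):

- compound 1, `Cc1cccc(N2CCN(CCCNc3nc(NCc4ccco4)c4ccccc4n3)CC2)c1C`, gives 94%
- compound 2, `Fc1ccc2nc(NCCCCN3CCN(c4cccc(Cl)c4Cl)CC3)nc(NCc3ccco3)c2c1`, gives 96.3%
- compound 3, `Cc1cccc(N2CCN(CCCNc3nc(NCc4ccco4)c4cc(F)ccc4n3)CC2)c1C`, gives 96.7%

All three compounds share a furanylmethylamino group and a basic piperazine linked through an alkyl chain, and all three give high numbers in this assay at the tested concentration. Compound 1 and compound 3 differ in exactly one place: hydrogen in place of fluoro on an aromatic carbon. This change gave a number 2.7 percentage points lower from compound 3 to compound 1 (within the scatter), so the fluorine on the fused aromatic ring did not move the read-out beyond the scatter of the method.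

Compound 4, `Clc1cccc(N2CCN(CCCCNc3nc(NCc4ccco4)c4ccccc4n3)CC2)c1Cl`, has not been measured. Within the data shown here, it differs from compound 2 by hydrogen in place of fluoro on an aromatic carbon, which is the same change as the one from compound 3 to compound 1. The difference between the core of compound 2 and the core of compound 3 is not broken down here, but the values of compound 2 and compound 3 lie close together.

Because the earlier step is a number 2.7 percentage points lower from compound 3 to compound 1 (within the scatter), the account expects a step of similar size, a number 2.3 percentage points lower from compound 2 to compound 4 (within the scatter), from compound 2 to compound 4 in this assay. On that basis compound 4 is estimated at 94%, with a range from 85% to 99%.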

Compound 4, a percentage reported as inhibition, at one concentration (the size of the read-out at that concentration, not a potency): 94.8%
Compound 4: middle estimate off by 0.8 percentage points, on the low side; measured number inside the range.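

In this assay, putting hydrogen in place of fluoro on the aromatic carbon of the fused ring system gave a number 1.5 percentage points lower from compound 2 to compound 4 (within the scatter), so on this second core too the change left the read-out inside the usual variation. Set beside the earlier step, the change reads the same on both cores, and within this small set it can be carried from one core to the other without a detectable difference: the same change on two cores in this assay, a number 2.7 percentage points lower (within the scatter) from compound 3 to compound 1 and a number 1.5 percentage points lower (within the scatter) from compound 2 to compound 4, 1.2 percentage points apart, within the scatter of two such steps

What carries over, however, is only the absence of a step beyond the scatter, on two cores and at a single concentration, so the pair of steps gives no sign that fluoro matters here and no measure of potency, and it does not show that the two steps would stay alike where the numbers have more room to move.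

The compounds shown leave open whether a methoxy or trifluoromethyl group on that same aromatic carbon would give a step beyond the scatter. They also leave open whether the fluoro-to-hydrogen change would read the same on a core with a longer chain to the piperazine, or with a benzyl group in place of the furanylmethyl group.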